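Aryl variation on the triazole nitrogen of a shared core

A few compounds are considered here, and "the series" means these few. Any claim that something is new, unique, unknown or untested is made for them only; others in the source may bear on it.

compound 1 `N#CC1=C(N)Oc2c(c3nc4ccccc4nc3c3ccccc23)C12C(=O)N(Cc1cnnn1-c1ccccc1Cl)c1ccccc12`: > 50000 nM
compound 2 `N#CC1=C(N)Oc2c(c3nc4ccccc4nc3c3ccccc23)C12C(=O)N(Cc1cnnn1-c1cccc(Br)c1)c1ccccc12`: > 50000 nM

In an ADME assay on HUVEC cells (Homo sapiens) for antiproliferative activity, read by MTT assay, with a stated time of 48 h (a lower number here means a stronger inhibitor, a higher number a weaker inhibitor), compound 1 gives > 50000 nM, which is a limit of the assay and not a number. Compound 2 gives > 50000 nM in this assay, again a limit. The step that the two limits leave unreadable from compound 1 to compound 2 is therefore unreadable. Compound 2 stands at the limit of > 50000 nM in this assay, at which 2 of the 2 values shown sit, with no measured number of its own. Compound 3 `CCOc1ccccc1-n1nncc1CN1C(=O)C2(C(C#N)=C(N)Oc3c2c2nc4ccccc4nc2c2ccccc32)c2ccccc21` differs from compound 2 by 2-ethoxyphenyl in place of 3-bromophenyl on an aromatic nitrogen. Only the unreadable step bears on this change, so no step beyond the scatter is expected in this assay. Compound 3 is expected at 60000 nM, between 20000 nM and 200000 nM, most likely a limit once more. The expected step is a step that the limit leaves unreadable from compound 2 to compound 3.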

Compound 3, half-maximal inhibitory concentration: > 50000 nM
Compound 3 ended at the assay's limit (the forecaster's own chance of this, stated with the estimate: 85%); the middle value lies beyond the limit too.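

For the compounds shown here, compound 1, compound 2 and compound 3 all sit at a limit, so no step among them can be read: the limit of > 50000 nM in this assay, at which 3 of the 3 values shown sit.
On these data alone, whether any aryl group on this aromatic nitrogen gives a measured number in this assay instead of a limit stays open.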